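Compound 4: phenyl in place of 2,4-dimethoxyphenyl

The source may hold more compounds than are shown below. What is called first, only, known or untested is meant among the compounds shown, and "the series" means these compounds.

Of the compounds shown here, three have values so far in a functional assay on MCF7 cells (Homo sapiens) for inhibition, read by fluorescence, with a stated time of 72 h (a higher number here means a weaker inhibitor of growth, a lower number a stronger inhibitor of growth), and they sit close together. Compound 1 (`COc1ccc(Nc2nc(N[C@H]3CC[C@H](N)CC3)nc3c2ncn3CCC(C)C)c(OC)c1`) stands at 6300 nM and does not separate from the other two. Compound 2 (`COc1ccc(Cn2cnc3c(Nc4cccc(Cl)c4)nc(N[C@H]4CC[C@H](N)CC4)nc32)cc1`) gives 4800 nM and compound 3 (`N[C@H]1CC[C@H](Nc2nc(Nc3ccc(O)cc3)c3ncn(C4CCCCC4)c3n2)CC1`) gives 9600 nM and both lie within the scatter of compound 1.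

The next compound is compound 4 (`CC(C)CCn1cnc2c(Nc3ccccc3)nc(N[C@H]3CC[C@H](N)CC3)nc21`). It differs from compound 1 in one place, with phenyl in place of 2,4-dimethoxyphenyl on a nitrogen on an aromatic ring. For the measured compounds named here, no two measured compounds differ in one place only, so the data give no direct reading of this change. Going by the values given here, the only guide is the narrow spread of the three values, although compound 2 and compound 3 differ from compound 1 in more than one place. In this assay no step beyond the scatter is therefore expected, and neither direction is favoured. The estimated change, a 1.1-fold lower number from compound 1 to compound 4 (0.02 log units; within the scatter) and so inside the scatter, is expected to be small. For compound 4 the expected value is 6000 nM with an estimated range from 2500 nM to 15000 nM in this assay.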

Compound 4, concentration for 50% growth inhibition: 5400 nM
Compound 4: middle estimate off by 1.1-fold (0.05 log units), on the high side; low and high end bracket the measured number.
By their numbers in this assay, from the lowest: compounds 2, 4, 1 and 3 (each within the scatter of the next).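

For the compounds shown here, replacing 2,4-dimethoxyphenyl with phenyl on a nitrogen on an aromatic ring gives a 1.2-fold lower number from compound 1 to compound 4 (0.07 log units; within the scatter) in this assay, the only direct reading so far at this position. In this pair, the (2,4-dimethoxyphenyl)amino to anilino change removes both oxygen-bearing substituents and leaves the ring as bare phenyl, yet the step stays inside the scatter, so the two methoxy groups are not needed to hold the value at this level of growth inhibition. Nothing measured here accounts for this flat result.

One step in one direction cannot show whether this position is insensitive in general, and compound 2 and compound 3 carry other aryl groups here but differ from compound 4 in more than one place, so those changes cannot be read. Still open, going by these compounds, is whether a group of a different kind on this nitrogen, such as a carboxylic acid or an aminomethyl on the phenyl ring, or a saturated cyclohexyl in place of the phenyl, would give a step beyond the scatter in either direction.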